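The compounds below may be only part of what the source reports. "The series", "measured", "known", "first", "only" and "open" are said of these compounds alone.

Measured so far in a functional assay on MDA-MB-468 cells (Homo sapiens) for cytotoxicity, read by MTT assay, with a stated time of 72 h; on this read-out lower numbers stand for stronger inhibition and higher numbers for weaker inhibition:
- compound 1 `Nc1nc(Nc2ccccc2)sc1C(=O)c1cccnc1`: "not determined" (no result reported)
- compound 2 `Nc1nc(Nc2ccccc2)sc1C(=O)c1ccc(F)cc1`: "not determined" (no result reported)
- compound 3 `Nc1nc(Nc2ccc(S(N)(=O)=O)cc2)sc1C(=O)c1cccnc1`: 2800 nM

Among the measured compounds shown here, compound 3 holds the only number, so it cannot be ranked against compound 1 or compound 2. Next is compound 4 `Nc1nc(Nc2ccc(S(N)(=O)=O)cc2)sc1C(=O)c1cccc(F)c1`, which has 3-fluorophenyl in place of pyridin-3-yl on a carbonyl carbon. For the measured compounds named here, no measured pair shows this exchange, so there is no direct precedent for its size. In this assay, a small shift towards stronger inhibition is expected, hardly beyond the scatter. The expected change is a 1.6-fold lower number from compound 3 to compound 4 (0.19 log units; within the scatter). Compound 4 is estimated at 1800 nM, with an expected range of 600 nM to 5500 nM.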

Compound 4, half-maximal inhibitory concentration: 800 nM
Compound 4: middle estimate off by 2.3-fold (0.35 log units), on the high side; the measured number falls inside the stated range.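

Among the compounds shown here, this is the first readable step: in this assay, 3-fluorophenyl in place of pyridin-3-yl on a carbonyl carbon gives a 3.5-fold lower number from compound 3 to compound 4 (0.54 log units; beyond the scatter). The position on the carbonyl carbon therefore responds to this exchange beyond the scatter, with the carbon-only ring on the side of stronger inhibition. No measured property bears on this shift. The compounds shown leave open whether the step follows the fluorine or the loss of the ring nitrogen. A plain phenyl group on the same carbonyl carbon would separate the two.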